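Swapping the base on a bicyclic sugar: cytotoxicity of compound 3

This account rests on a few compounds, and the source may have more. Where it says the series, first, only, none or still open, it means among the compounds named here.

Compound 1 `CN(C)c1ncnc2c1ncn2[C@@H]1O[C@H](CO[Si](C)(C)C(C)(C)C)[C@@]2(OS(=O)(=O)C=C2N)[C@H]1O[Si](C)(C)C(C)(C)C` is the reference point of this small series. In a functional assay on MT4 cells (Homo sapiens) for cytotoxicity (on this read-out lower numbers stand for higher toxicity in this test and higher numbers for lower toxicity in this test), compound 1 gives 15000 nM, the only numerical result in the set. The other result is a limit of the assay: compound 2 `CC(C)(C)[Si](C)(C)OC[C@H]1O[C@@H](n2cnc3ncn([C@@H]4O[C@H](CO[Si](C)(C)C(C)(C)C)[C@@]5(OS(=O)(=O)C=C5N)[C@H]4O[Si](C)(C)C(C)(C)C)c3c2=O)[C@H](O[Si](C)(C)C(C)(C)C)[C@]12OS(=O)(=O)C=C2N` reaches only > 150000 nM, at which one of the two values sits (the limit of > 150000 nM in this assay, at which 1 of the 2 values shown sits). Among the compounds with values here, no measured step between compounds differing in one place is available. Compound 3 `CC(C)(C)[Si](C)(C)OC[C@H]1O[C@@H](n2cnc3ccccc32)[C@H](O[Si](C)(C)C(C)(C)C)[C@]12OS(=O)(=O)C=C2N` differs from compound 1 in one place: a group of 9 heavy atoms (7 carbon, 2 nitrogen; one five-membered aromatic ring with 2 hetero atoms, one six-membered aromatic ring of carbon only) in place of a group of 12 heavy atoms (7 carbon, 5 nitrogen; one five-membered aromatic ring with 2 hetero atoms, one six-membered aromatic ring with 2 hetero atoms), on a saturated ring carbon. Within the data shown here, with no comparable step to lean on, the account expects a modest shift toward lower toxicity, of a size that may still sit within the usual scatter; the expected step from compound 1 to compound 3 is a 2.0-fold higher number from compound 1 to compound 3 (0.30 log units; within the scatter). For compound 3 the estimated half-maximal cytotoxic concentration in this assay is 30000 nM, with a range from 8000 nM to 150000 nM.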

Compound 3, half-maximal cytotoxic concentration: 15000 nM
Estimate against measurement, compound 3: 2.0-fold (0.30 log units) above, within the range that was stated.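

Exchanging the group of compound 1 for 1H-benzimidazol-1-yl on this saturated ring carbon, next to the ring oxygen, gives in this assay a step of no change at the digits printed from compound 1 to compound 3 (within the scatter). Within the data shown here, this is the first comparison at this position, and it shows that a six-membered aromatic ring of carbon only can stand in place of a six-membered aromatic ring with 2 hetero atoms without a change that can be read in this test. Nothing at hand accounts for this result.

The compounds shown leave open whether a smaller group on the same carbon, such as an imidazole ring alone, would also leave the read-out unchanged. They also leave open what a primary amine or a carboxylic acid on the benzimidazole ring would do.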